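The source may hold more compounds than are shown below. What is called first, only, known or untested is meant among the compounds shown, and "the series" means these compounds.

Measured so far:
- compound 1, `O=C1C2CCCN2C(=O)N1CCN1CCN(c2ccc(F)cc2)CC1`, > 1000 nM
- compound 2, `O=C1C2CCCN2C(=O)N1CCN1CCN(c2ccc([N+](=O)[O-])cc2)CC1`, > 10000 nM
- compound 3, `O=C1C2CCCN2C(=O)N1CCCN1CCN(c2ccc(F)cc2)CC1`, 25.2 nM

All three were tested in an assay on isolated protein for binding affinity to Adrenergic receptor alpha-1 (Rattus norvegicus), read by radioligand binding; a lower number here means a stronger inhibitor, a higher number a weaker inhibitor. For compound 1 the value > 1000 nM is a limit of the assay and not a number, as the limit of > 1000 nM in this assay, at which 1 of the 3 values shown sits, shows. For compound 2 the value > 10000 nM is likewise a limit, as the limit of > 10000 nM in this assay, at which 1 of the 3 values shown sits, shows. Compound 3 is the only one of the three with a measured number, giving 25.2 nM in this assay.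

Compound 1 and compound 2 differ by one change, (nitro in place of fluoro on an aromatic carbon). Because both values are limits, the step that the two limits leave unreadable from compound 1 to compound 2 cannot be read in size. The difference between the core of compound 1 and the core of compound 3 is not broken down here.

Compound 4, `O=C1C2CCCN2C(=O)N1CCCN1CCN(c2ccc([N+](=O)[O-])cc2)CC1`, has not yet been measured. It stands to compound 3 as compound 2 stands to compound 1: the change is nitro in place of fluoro on an aromatic carbon, the same change in the same place. The earlier instance gives no readable size, so the expectation for compound 4 rests on compound 3 alone, whose value 25.2 nM is the only number shown. Compound 4 is expected to give about 70 nM in this assay. That estimate means a step of a 2.8-fold higher number from compound 3 to compound 4 (0.44 log units; beyond the scatter), with a wide range from 15 nM to 400 nM, since the step cannot be anchored by the earlier pair.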

Compound 4, inhibition constant: > 1000 nM
Compound 4: a limit, no number; the forecaster's own chance of this, stated with the estimate: 10%; middle value at least 14-fold (1.15 log units) away from the limit.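

On the core of compound 3, the change to 4-nitrophenyl from 4-fluorophenyl is costly in this assay: it gives an at least 39-fold higher number from compound 3 to compound 4 (1.59 log units; beyond the scatter), and the real step could be larger still. Compound 4 gives > 1000 nM, which is a limit of the assay and not a number: the limit of > 1000 nM in this assay, at which 2 of the 4 values shown sit. Among these compounds, the same change on the core of compound 1 leaves a step that cannot be read, so only one of the two cores gives any size, and nothing here shows that this size carries over from one core to the other.

Among the compounds shown, only fluoro and nitro occupy this place on the aromatic ring, so it stays open whether the large loss belongs to nitro alone or would also appear with another group there, such as an amine, a methoxy group or a chlorine atom. Also open, on these data alone, is how a longer chain than that of compound 3 would read with fluoro or with nitro, and whether any group on the core of compound 1 would give a measured number that could turn the unreadable step into a real comparison.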